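A few compounds are considered here, and "the series" means these few. Any claim that something is new, unique, unknown or untested is made for them only; others in the source may bear on it.

Measured so far in an in vivo functional assay on the whole organism for inhibition, with Rattus norvegicus as the target; on this read-out higher numbers stand for an effect only at larger amounts of compound and lower numbers for an effect already at smaller amounts:
compound 1 `CCCCc1nc(C)c(CCC(=O)OCC)c(=O)n1Cc1ccc(-c2ccccc2-c2nnn[nH]2)cc1`: 0.066 mg/kg
compound 2 `CCCCc1nc(C)c(CCC(=O)N2CCC[C@H]2C(=O)OC)c(=O)n1Cc1ccc(-c2ccccc2-c2nnn[nH]2)cc1`: 0.063 mg/kg

Going by the values given here, the two numbers give no order, and compound 2 stands level with the only other measured compound: a 1.0-fold lower number from compound 1 to compound 2 (0.02 log units; within the scatter). Next in this assay is compound 3 `CCCCc1nc(C)c(CCC(=O)N2CC(C)OC(C)C2)c(=O)n1Cc1ccc(-c2ccccc2-c2nnn[nH]2)cc1`, with 2,6-dimethylmorpholin-4-yl in place of 2-(methoxycarbonyl)pyrrolidin-1-yl on a carbonyl carbon. Among the compounds with values here, one measured step bears on this, the replacement of ethoxy on the same carbonyl carbon, and it stayed within the scatter: a 1.0-fold lower number from compound 1 to compound 2 (0.02 log units; within the scatter). Within the data shown here, no measured compound carries the 2,6-dimethylmorpholin-4-yl group, so this single step is thin support. The expected result is no change beyond the scatter, with an estimated 1.3-fold higher number from compound 2 to compound 3 (0.10 log units; within the scatter). For compound 3 the estimated value is 0.08 mg/kg, with an expected range of 0.025 mg/kg to 0.25 mg/kg.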

Compound 3, dose for half-maximal effect: 0.228 mg/kg
The estimate for compound 3 lay 2.9-fold (0.45 log units) below the measured number; the range from low to high includes it.
By their numbers in this assay, from the lowest: compounds 2 and 1 (each within the scatter of the next); then compound 3.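

In this assay this carbonyl carbon turns out not to accept every group equally: a 3.6-fold higher number from compound 2 to compound 3 (0.56 log units; beyond the scatter) for 2,6-dimethylmorpholin-4-yl in place of 2-(methoxycarbonyl)pyrrolidin-1-yl, and a 3.5-fold higher number from compound 1 to compound 3 (0.54 log units; beyond the scatter) for the same group in place of ethoxy. Ethoxy and 2-(methoxycarbonyl)pyrrolidin-1-yl gave no such separation, since a 1.0-fold lower number from compound 1 to compound 2 (0.02 log units; within the scatter) stays within the scatter, so 2,6-dimethylmorpholin-4-yl is the first group here to stand apart, by a modest step from each of the other two. Nothing available accounts for this higher number.

Still open, going by these compounds, is whether the shift goes with the six-membered ring, its oxygen or its two methyl groups, which unsubstituted morpholin-4-yl and piperidin-1-yl would help to separate. Also open, on these data alone, is how a free carboxylic acid in place of the methyl ester on the pyrrolidine ring would read.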